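The source may report more compounds than this note shows. Statements on the series, on what has been measured and on what is new or still open speak of the compounds shown alone.

Measured so far:
compound 1, `COc1ccc2nc(C)cc(OCC(=O)NCc3cc(C)cc(C)c3)c2c1`, 5.25
compound 2, `COc1ccc2nc(C)cc(NCC(=O)Nc3cc(C)cc(C)c3)c2c1`, 3.59
compound 3, `COc1ccc2nc(C)cc(OCC(=O)Nc3cc(OC)c(OC)c(OC)c3)c2c1`, 3.95

In a physicochemical assay for lipophilicity, read by HPLC, in phosphate buffer, measured as chromatographic lipophilicity, at pH 7.4 (on this read-out lower numbers stand for lower lipophilicity and higher numbers for higher lipophilicity), compound 1 stands highest of the three numbers; compound 3 lies nearest to it, lower by a step beyond the scatter, and compound 2 lies furthest, lower still and likewise beyond the scatter. Among the compounds with values here, no step between measured compounds that differ in one place is available, so the comparison rests on the set as a whole. Compound 4 is `COc1ccc2nc(C)cc(OCC(=O)Nc3nccs3)c2c1`; it differs from compound 1 by 1,3-thiazol-2-yl in place of 3,5-dimethylbenzyl on an amide-type nitrogen, a group of 9 heavy atoms leaving and a group of 5 heavy atoms carrying 2 hydrogen-bond acceptors entering. A drop beyond the scatter is expected, the step of a number 1.85 log units lower from compound 1 to compound 4 (beyond the scatter) being the estimate. In this assay compound 4 is expected to give about 3.4, within a range from 2.8 to 4.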

Compound 4, distribution coefficient: 3.2
Beside the measured number, compound 4's estimate is 0.20 log units above it; the measured number falls inside the stated range.
By their numbers in this assay, from the lowest: compound 4; then compound 2; then compound 3; then compound 1.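

The amide-type nitrogen is a position where the group carried strongly moves the read-out in this assay: 1,3-thiazol-2-yl in place of 3,5-dimethylbenzyl gives a number 2.05 log units lower from compound 1 to compound 4 (beyond the scatter) and is a large step. Within the data shown here, this is the first change that can be read at one place, as the earlier compounds offered no such pair. Nothing at hand accounts for the size of this step.

The change swaps a larger carbon-only group for a smaller one with hetero atoms, so these two differences remain unseparated. Open too, on these data alone, is how an unsubstituted phenyl or a 2-pyridyl group on the same nitrogen would read.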